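Thiophene carboxamide series: acyl aryl swap, compound 3

The source may hold more compounds than are shown below. What is called first, only, known or untested is meant among the compounds shown, and "the series" means these compounds.

For the measured compounds named here, compound 2 `NC(=O)c1c(NC(=O)c2ccccc2F)sc2c1CCN(C(=S)Nc1ccccc1Cl)C2` is the weaker inhibitor of the two compounds measured so far in a functional assay on MKN-74 cells (Homo sapiens) for antiproliferative activity, with a stated time of 24 h (on this read-out higher numbers stand for weaker inhibition and lower numbers for stronger inhibition), where compound 2 gives 11100 nM; its only neighbour, compound 1 `NC(=O)c1c(NC(=O)c2ccccc2F)sc2c1CCN(Cc1c(Cl)cccc1Cl)C2`, gives 7430 nM, and the step of a 1.5-fold higher number from compound 1 to compound 2 (0.17 log units; within the scatter) lies within the scatter, so the two stand level rather than in order. Compound 3 `NC(=O)c1c(NC(=O)c2cccc([N+](=O)[O-])c2)sc2c1CCN(C(=S)Nc1ccccc1Cl)C2` is not yet measured. It differs from compound 2 in one place: 3-nitrophenyl in place of 2-fluorophenyl on a carbonyl carbon. Going by the values given here, the only measured step concerns the group on the amine nitrogen in the ring, not the acyl group, so no measured step bears on this change, and the expectation rests on the unchanged remainder of compound 2 alone. For compound 3 no step beyond the scatter is expected, a 1.0-fold lower number from compound 2 to compound 3 (0.00 log units; within the scatter), with a wide range to reflect the absence of any guiding comparison. Compound 3 is therefore estimated at 11000 nM, between 3500 nM and 35000 nM.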

Compound 3, half-maximal inhibitory concentration: 8850 nM
Beside the measured number, compound 3's estimate is 1.2-fold (0.09 log units) above it; the measured number falls inside the stated range.
By their numbers in this assay, from the lowest: compounds 1, 3 and 2 (each within the scatter of the next).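

Working notes: this is the first measured change at the acyl aryl group, with the group on the amine nitrogen in the ring held fixed. In this assay the swap of 2-fluorophenyl for 3-nitrophenyl on a carbonyl carbon gives a 1.3-fold lower number from compound 2 to compound 3 (0.10 log units; within the scatter) and so leaves compound 2 and compound 3 level, even though the entering group carries hydrogen-bond acceptors that the leaving group lacks. No supporting data bear on this result.

Both aryl groups shown are six-membered aromatic rings of carbon only, so it stays open whether a cyclohexyl group, or a phenyl ring carrying an amine or a carboxylic acid, would give a step beyond the scatter. As far as these compounds go, it also stays open whether 3-nitrophenyl would read the same with the amine-nitrogen group of compound 1.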